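From Pyridin-3-yl to 1-Methyl-1H-pyrazol-4-yl on a Shared Core

The source may report more compounds than this note shows. Statements on the series, on what has been measured and on what is new or still open speak of the compounds shown alone.

Compound 3 `CNC(=O)N1CCCc2ccc(NC(=O)c3ccc(-c4cccnc4)cc3)cc21` carries a pyridin-3-yl group and gives 92.1% in a functional assay on MV4-11 cells (Homo sapiens) for antiproliferative activity, with a stated time of 6 days, tested at 6.25 uM (a lower number here means a weaker effect, a higher number a stronger effect of the compound at the concentration tested), the highest of the three numbers measured. Compound 1 `CNC(=O)N1CCCc2ccc(NC(=O)c3ccc(-c4ccccc4)cc3)cc21` gives 74.3%, and compound 2 `CNC(=O)N1CCCc2ccc(NC(=O)c3ccc(-c4cnn(S(C)(=O)=O)c4)cc3)cc21` gives 40.2%. The step of a number 17.8 percentage points higher from compound 1 to compound 3 (beyond the scatter) is modest, while the step of a number 51.9 percentage points higher from compound 2 to compound 3 (beyond the scatter) is large, as is the step of a number 34.1 percentage points lower from compound 1 to compound 2 (beyond the scatter).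

Compound 4 `CNC(=O)N1CCCc2ccc(NC(=O)c3ccc(-c4cnn(C)c4)cc3)cc21` has not yet been measured. It differs from compound 3 in one place: 1-methyl-1H-pyrazol-4-yl in place of pyridin-3-yl on an aromatic carbon. Among the compounds with values here, two measured steps bear on this change. The step of a number 34.1 percentage points lower from compound 1 to compound 2 (beyond the scatter) shows that 1-(methylsulfonyl)-1H-pyrazol-4-yl falls far short of phenyl, while the step of a number 17.8 percentage points higher from compound 1 to compound 3 (beyond the scatter) shows that pyridin-3-yl rises above phenyl. Within the data shown here, a 1-methyl-1H-pyrazol-4-yl has no measured counterpart here, so a drop in this assay is expected, smaller than the one seen for compound 2 but likely beyond the scatter. Compound 4 is therefore expected to give 70%, within a range of 45% to 90%. This estimate implies an expected step of a number 22.1 percentage points lower from compound 3 to compound 4 (beyond the scatter).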

Compound 4, a percentage reported as inhibition, at one concentration (the size of the read-out at that concentration, not a potency): 94.4%
Compound 4: middle estimate off by 24.4 percentage points, on the low side, outside the stated range (above it).
By their numbers in this assay, from the lowest: compound 2; then compound 1; then compounds 3 and 4 (each within the scatter of the next).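

Read in this assay, the five-membered 1-methyl-1H-pyrazol-4-yl and the six-membered pyridin-3-yl cannot be told apart at this position, para to a large group, with a number 2.3 percentage points higher from compound 3 to compound 4 (within the scatter). The low number of compound 2 therefore does not go with the pyrazole ring itself, since methyl in place of methylsulfonyl on the aromatic nitrogen gives a number 54.2 percentage points higher from compound 2 to compound 4 (beyond the scatter), while 1-methyl-1H-pyrazol-4-yl in place of phenyl gives a number 20.1 percentage points higher from compound 1 to compound 4 (beyond the scatter), a modest step. Nothing shown here explains why these groups differ or match.

The compounds shown leave open whether the pyrazole nitrogen tolerates anything larger than methyl, such as a longer chain or one ending in an amine. Because this read-out comes from one concentration, it also leaves open whether compound 3 and compound 4 would separate in potency.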